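The source may report more compounds than this note shows. Statements on the series, on what has been measured and on what is new or still open speak of the compounds shown alone.

Two members of the series are in hand. Compound 1 `Cc1ccc2nc(/N=C3\C(=O)N(CN4CCCCC4)c4ccccc43)sc2c1` carries piperidin-1-yl on the saturated chain carbon and no bromine; in a functional assay on MDA-MB-468 cells (Homo sapiens) for cytotoxicity, read by sulforhodamine B assay, with a stated time of 48 h (a higher number here means a weaker inhibitor of growth, a lower number a stronger inhibitor of growth), compound 1 gives 65600 nM. Compound 2 `Cc1ccc2nc(/N=C3\C(=O)N(CN(C)C)c4cccc(Br)c43)sc2c1` carries dimethylamino and a bromine; in this assay compound 2 gives 27400 nM, the lower of the two numbers, with compound 1 as its nearest neighbour at a gap beyond the scatter. Going by the values given here, compounds 1 and 2 differ in two places, so no single step connects them and neither change can be credited with that gap.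

Compound 3 `Cc1ccc2nc(/N=C3\C(=O)N(CN4CCCCC4)c4cccc(Br)c43)sc2c1` follows from compound 2 by one change: piperidin-1-yl in place of dimethylamino on a saturated chain carbon bound to an amide-type nitrogen in a ring. Among the compounds with values here, no measured pair isolates this change, so the expected direction rests on compound 1 alone, which shares the piperidin-1-yl group but not the bromine. The step from compound 2 to compound 3 is expected to be small, a 1.4-fold higher number from compound 2 to compound 3 (0.14 log units; within the scatter), tending towards a higher number.

Compound 3 is expected to give 38000 nM in this assay, within 13000 nM to 110000 nM.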

Compound 3, concentration for 50% growth inhibition: 24000 nM
Compound 3: middle estimate off by 1.6-fold (0.20 log units), on the high side; the range from low to high includes it.
By their numbers in this assay, from the lowest: compounds 3 and 2 (each within the scatter of the next); then compound 1.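

In this assay, with the bromine kept, piperidin-1-yl in place of dimethylamino on a saturated chain carbon bound to an amide-type nitrogen in a ring gives a 1.1-fold lower number from compound 2 to compound 3 (0.06 log units; within the scatter), so the larger ring-bearing amine and the smaller open one cannot be told apart at this position. Going by these compounds alone, with piperidin-1-yl kept, bromo in place of hydrogen on an aromatic carbon gives a 2.7-fold lower number from compound 1 to compound 3 (0.44 log units; beyond the scatter), a modest step and the only single-place step so far that lies beyond the scatter. No measurement shown here offers an explanation for either step.

As far as these compounds go, whether the bromo step also holds with dimethylamino on the chain carbon remains open. Also open, from the compounds shown here alone, are chloro on that aromatic carbon and morpholin-4-yl on the chain carbon, either of which might read differently.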